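This account rests on a few compounds, and the source may have more. Where it says the series, first, only, none or still open, it means among the compounds named here.

Measured compounds:
compound 1 `COc1ccc(-c2nc(C)oc2C(=O)N2CCN(c3cccc(Cl)c3)CC2)cc1`: "not active" (no number reported)
compound 2 `CCc1nc(-c2ccc(OC)cc2)c(C(=O)N2CCN(c3cccc(Cl)c3)CC2)o1`: > 1000 nM
compound 3 `COc1cc(OC)cc(N2CCN(C(=O)c3oc(C)nc3-c3cccc(F)c3)CC2)c1`: 28.2 nM

In a functional assay on HL-60 cells (Homo sapiens) for inhibition, read by MTT assay, with a stated time of 72 h (a higher number here means a weaker inhibitor, a lower number a stronger inhibitor), compound 1 is reported only as "not active" (no number reported), with no number attached, so it has no fixed place on the scale. Compound 2 gives a limit of the assay, > 1000 nM. This is the limit of > 1000 nM in this assay, at which 1 of the 3 values shown sits. Within the data shown here, compound 3 gives 28.2 nM, the only value here that carries a number. No two of these compounds differ in one place, so no measured step is available. Compound 4 `Cc1nc(-c2cccc(O)c2)c(C(=O)N2CCN(c3cccc(Cl)c3)CC2)o1` differs from compound 1 by 3-hydroxyphenyl in place of 4-methoxyphenyl on an aromatic carbon. Among the measured compounds shown here, with no measured step to lean on, a move toward stronger inhibition in this assay is possible but of unknown size, and a result at the limit cannot be excluded. Compound 4 is expected to give about 2000 nM, within 300 nM to 15000 nM.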

Compound 4, half-maximal inhibitory concentration: 105 nM
Compound 4: middle estimate off by 19-fold (1.28 log units), on the high side; the measured number lies below the stated range.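

No step can be read from compound 1, reported as "not active" (no number reported), to compound 4. The compounds shown leave open how large a change in inhibition 3-hydroxyphenyl brings in place of 4-methoxyphenyl.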